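The compounds below may be only part of what the source reports. "The series", "measured", "known", "first", "only" and "open" are said of these compounds alone.

Compound 1, whose structure is `Cn1c(/C=C/C(=O)c2ccccc2O)cc(Br)c1Br`, was tested in a functional assay on MCF7 cells (Homo sapiens) for cytotoxicity, read by MTT assay, with stated times of 6 h and 48 h (on this read-out higher numbers stand for weaker inhibition and lower numbers for stronger inhibition), and gave 2510 nM. Compound 2, with the structure `O=C(/C=C/c1cc(Br)c(Br)[nH]1)c1ccccc1O`, differs from it in one place: hydrogen in place of methyl on an aromatic nitrogen. In this assay compound 2 gave 1490 nM, and the step is a 1.7-fold lower number from compound 1 to compound 2 (0.23 log units; within the scatter), so exchanging the methyl for a hydrogen at that nitrogen left the read-out essentially where it was.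

Compound 3 has the structure `Cn1c(-c2cc(-c3ccccc3O)no2)cc(Br)c1Br`. How its core differs from the core of compound 1 is not broken down here. In this assay compound 3 reached only the limit of the measurement, >= 100000 nM, which is a boundary of what the assay reports and not a number; this is the case described by the limit of >= 100000 nM in this assay, at which 1 of the 3 values shown sits.

Compound 4, with the structure `Oc1ccccc1-c1cc(-c2cc(Br)c(Br)[nH]2)on1`, has not yet been measured. It stands to compound 3 as compound 2 stands to compound 1, since the change is hydrogen in place of methyl on an aromatic nitrogen, the same change as before. The expectation for compound 4 therefore rests on the step from compound 1 to compound 2, which was a 1.7-fold lower number from compound 1 to compound 2 (0.23 log units; within the scatter), and on the limit that compound 3 showed. On that basis the step from compound 3 to compound 4 is expected to be about a number no higher from compound 3 to compound 4 (the limit leaves the size open). Compound 4 is estimated to give roughly 100000 nM, most likely between 40000 nM and 300000 nM, and quite possibly it will again reach only the limit of this assay.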

Compound 4, half-maximal inhibitory concentration: >= 100000 nM
Compound 4 gave a limit, no number; the forecaster's own chance of this, stated with the estimate: 70%; the middle value sits exactly at the limit.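

In this assay compound 4 gives >= 100000 nM, which is a limit of the assay and not a number. Compound 3 also stands at a limit, so no step from compound 3 to compound 4 can be read: the limit of >= 100000 nM in this assay, at which 2 of the 4 values shown sit.

The compounds shown leave open what numbers compound 3 and compound 4 would give, and so whether hydrogen in place of methyl on the aromatic nitrogen changes anything in this pair.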